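Swapping the Ring Pair on the Sulfonyl Sulfur

The compounds below may be only part of what the source reports. "The series", "measured", "known", "first", "only" and "open" are said of these compounds alone.

Compound 1 `O=C1[C@@H](NS(=O)(=O)c2ccc(-c3ccon3)s2)CCN1Cc1cc2c[nH]ccc-2n1` and compound 2 `O=C1[C@@H](NS(=O)(=O)c2ccc(-c3ccncc3)s2)CCN1Cc1cc2c[nH]ccc-2n1` share one core and differ only in the group attached to the sulfonyl sulfur. In an assay on isolated protein for inhibition of coagulation factor X (Oryctolagus cuniculus), tested at 1 uM (on this read-out higher numbers stand for more inhibition at the one concentration tested (going by the name of the read-out) and lower numbers for less inhibition), compound 1 gives 17%, and compound 2 gives 21%. The step of a number 4 percentage points higher from compound 1 to compound 2 (within the scatter) lies within the scatter, so the two numbers cannot be told apart. Compound 1 thus stands as the lower of the two numbers, but only by a margin the scatter swallows.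

Compound 3 `O=C1[C@@H](NS(=O)(=O)c2cc3nc(Cl)ccc3s2)CCN1Cc1cc2c[nH]ccc-2n1` is not yet measured. It differs from compound 1 as follows: a group of 10 heavy atoms (7 carbon, 1 nitrogen, 1 sulfur, 1 chlorine; one five-membered aromatic ring with 1 hetero atom, one six-membered aromatic ring with 1 hetero atom) in place of a group of 10 heavy atoms (7 carbon, 1 nitrogen, 1 oxygen, 1 sulfur; one five-membered aromatic ring with 1 hetero atom, one five-membered aromatic ring with 2 hetero atoms), on a sulfonyl sulfur. Within the data shown here, the only step available, a number 4 percentage points higher from compound 1 to compound 2 (within the scatter), exchanged a single ring on the same sulfonyl sulfur and moved nothing beyond the scatter; no measured step replaces the whole group with a fused ring pair. For compound 3 the expected step is therefore a number 3 percentage points higher from compound 1 to compound 3 (within the scatter), no more than the scatter. Compound 3 is estimated at 20%, between 5% and 45%.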

Compound 3, a percentage reported as inhibition, at one concentration (the size of the read-out at that concentration, not a potency): 58%
Compound 3: middle estimate off by 38 percentage points, on the low side; the whole stated range lies below it.
By their numbers in this assay, from the lowest: compounds 1 and 2 (each within the scatter of the next); then compound 3.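

Changes on this sulfonyl sulfur can move the number in this assay far more than the single ring exchange suggested: the new replacement gives a number 41 percentage points higher from compound 1 to compound 3 (beyond the scatter) and so stands clear of the scatter. The leaving and entering groups have the same count of 10 heavy atoms, so that count alone does not separate them; they differ in their atoms and rings, with the entering group carrying a chlorine and a six-membered aromatic ring. No measurement at hand gives a reason for the rise.

This one step changes several features at once, so the share of the chlorine cannot be separated from that of the six-membered ring. On these data alone, it remains open whether the number would hold with a hydrogen, a methyl or a bromine in place of the chlorine.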